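The source may report more compounds than this note shows. Statements on the series, on what has been measured and on what is new or still open speak of the compounds shown alone.

Measured so far, in an ADME assay on RAW264.7 cells (Mus musculus) for cytotoxicity, read by MTT assay, with a stated time of 72 h, tested at 100 uM; on this read-out higher numbers stand for a stronger effect at the one concentration tested and lower numbers for a weaker effect:
compound 1 `O=C(Cn1c(=O)oc2ccccc21)Nc1nc2ccc([N+](=O)[O-])cc2s1` gives 19.2%
compound 2 `O=C(Cn1c(=O)oc2cc(Cl)ccc21)Nc1nc2ccc([N+](=O)[O-])cc2s1` gives 14.2%
compound 3 `O=C(Cn1c(=O)oc2ccccc21)Nc1ccccn1` gives 28.4%

Compound 1 and compound 2 share one core and differ only by chloro in place of hydrogen on an aromatic carbon; in this assay this gives a number 5 percentage points lower from compound 1 to compound 2 (within the scatter). Compound 3 carries a different core; the difference between the two cores is not broken down here. The value of compound 3 lies within the usual scatter of that of compound 1 and beyond it only relative to compound 2.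

Compound 4 `O=C(Cn1c(=O)oc2cc(Cl)ccc21)Nc1ccccn1` is not yet measured. It differs from compound 3 by chloro in place of hydrogen on an aromatic carbon, the same change as from compound 1 to compound 2. In this assay the expected step is a number 5.4 percentage points lower from compound 3 to compound 4 (within the scatter), resting on the small step of a number 5 percentage points lower from compound 1 to compound 2 (within the scatter) seen on the other core. Compound 4 is therefore estimated at 23%, expected to lie between 10% and 36%.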

Compound 4, a percentage reported as inhibition, at one concentration (the size of the read-out at that concentration, not a potency): 43.7%
For compound 4 the middle estimate is 20.7 percentage points below the measured one, and the stated range ends below it.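

In this assay, chloro in place of hydrogen on an aromatic carbon gives a number 15.3 percentage points higher from compound 3 to compound 4 (beyond the scatter), so the step seen on the core of compound 1 does not carry over to the core of compound 3: the same change on two cores in this assay, a number 5 percentage points lower (within the scatter) from compound 1 to compound 2 and a number 15.3 percentage points higher (beyond the scatter) from compound 3 to compound 4, 20.3 percentage points apart, beyond the scatter of two such steps

A step read on one of these cores therefore gives no safe estimate for the same change on the other. What remains unshown is why the cores differ, since the difference between them is not broken down and two pairs give no rule for any further core.

Open, going by these compounds, is whether fluoro, bromo or methoxy in the same place would follow chloro on each core. Also open, on these data alone, is whether an amine or a carboxylic acid there would separate the two cores in the same way.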